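An Ester Gives Way to a Primary Amide

The source may hold more compounds than are shown below. What is called first, only, known or untested is meant among the compounds shown, and "the series" means these compounds.

Within the data shown here, compound 3 `CCOC(=O)CCCN1CCC(CCCn2c(COc3ccc(Cl)cc3)nc3c(C)cccc32)CC1` gives 29 nM in an assay on AV12 cells for binding affinity to Neuropeptide Y receptor type 1 (Homo sapiens) (on this read-out higher numbers stand for weaker inhibition and lower numbers for stronger inhibition), the second highest of the three numbers known. In this assay compound 1 `Cc1cccc2c1nc(COc1ccc(Cl)cc1)n2CCCC1CCN(C)CC1` gives 52 nM and compound 2 `Cc1cccc2c1nc(COc1ccc(Cl)cc1)n2CCCC1CCN(CCC(C)C)CC1` gives 11 nM. Compound 4 `Cc1cccc2c1nc(COc1ccc(Cl)cc1)n2CCCC1CCN(CCCC(N)=O)CC1` differs from compound 3 by amino in place of ethoxy on a carbonyl carbon. Among the measured compounds shown here, no measured step alters the carbonyl substituent itself; the nearest precedents concern the whole chain on the ring nitrogen: a 1.8-fold lower number from compound 1 to compound 3 (0.25 log units; within the scatter) and a 2.6-fold higher number from compound 2 to compound 3 (0.42 log units; beyond the scatter), while a 4.7-fold lower number from compound 1 to compound 2 (0.67 log units; beyond the scatter). Since the chain end has so far moved this assay only modestly, the change from ester to amide is expected to give a step of a 1.2-fold higher number from compound 3 to compound 4 (0.08 log units; within the scatter), within the usual scatter. Compound 4 is therefore estimated at 35 nM, with a range from 12 nM to 100 nM.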

Compound 4, inhibition constant: 88 nM
Beside the measured number, compound 4's estimate is 2.5-fold (0.40 log units) below it; low and high end bracket the measured number.
By their numbers in this assay, from the lowest: compound 2; then compounds 3, 1 and 4 (each within the scatter of the next, the first and the last beyond it).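

In this assay, the carbonyl substituent itself proves to matter: amino in place of ethoxy on a carbonyl carbon gives a 3.0-fold higher number from compound 3 to compound 4 (0.48 log units; beyond the scatter) on its own, so a change confined to the chain end moves the number beyond the scatter. Among these compounds, the amide chain also gives an 8.0-fold higher number from compound 2 to compound 4 (0.90 log units; beyond the scatter) and the widest step so far, while a 1.7-fold higher number from compound 1 to compound 4 (0.23 log units; within the scatter) amounts to no real change. Nothing available bears on the reason for the step from ester to amide. Going by these compounds, whether a carboxylic acid or a secondary amide would track the ester or the primary amide stays open, as does the effect of a longer chain ending in carbamoyl.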